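Swapping tert-butyl for an ester-bearing group on the amine

A few compounds are considered here, and "the series" means these few. Any claim that something is new, unique, unknown or untested is made for them only; others in the source may bear on it.

Values measured in a functional assay on SK-BR-3 cells (Homo sapiens) for antiproliferative activity (on this read-out higher numbers stand for weaker inhibition and lower numbers for stronger inhibition), are these
- Compound 1 `CC(C)=CCc1cc(C(=O)Nc2cc3ccc(OCC4CCCNC4)c(C)c3oc2=O)ccc1O` gives 600 nM
- Compound 2 `CC(C)=CCc1cc(C(=O)Nc2cc3ccc(OCCCNCC(C)C)c(C)c3oc2=O)ccc1O` gives 1030 nM
- Compound 3 `CC(C)=CCc1cc(C(=O)Nc2cc3ccc(OCCCNC(C)(C)C)c(C)c3oc2=O)ccc1O` gives 660 nM

All three compounds share one core and differ only in the amine-bearing chain. Compound 3 stands close to both of the others, since the data show a 1.1-fold higher number from compound 1 to compound 3 (0.04 log units; within the scatter) and a 1.6-fold lower number from compound 2 to compound 3 (0.19 log units; within the scatter) on the same read-out.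

Among the compounds with values here, the next molecule is compound 4 `COC(=O)CNCCCOc1ccc2cc(NC(=O)c3ccc(O)c(CC=C(C)C)c3)c(=O)oc2c1C` and its single change is (methoxycarbonyl)methyl in place of tert-butyl on an amine nitrogen in which (methoxycarbonyl)methyl takes the place of tert-butyl on an amine nitrogen.

The nearest evidence is the swap of isobutyl for tert-butyl on that nitrogen, already given above as the step to compound 3. Larger rewrites of the side chain also stayed small, as seen in a 1.7-fold higher number from compound 1 to compound 2 (0.23 log units; within the scatter) and in a 1.1-fold higher number from compound 1 to compound 3 (0.04 log units; within the scatter). Within the data shown here, no measured compound carries a (methoxycarbonyl)methyl group, however, so the range has to stay wide. In this assay no step beyond the scatter is therefore expected, and the direction is uncertain.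

The estimated step is a 1.4-fold higher number from compound 3 to compound 4 (0.13 log units; within the scatter) and remains modest. For compound 4 the expected value is 900 nM within an estimated range of 350 nM to 2300 nM on this read-out.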

Compound 4, half-maximal inhibitory concentration: 1060 nM
Beside the measured number, compound 4's estimate is 1.2-fold (0.07 log units) below it; measured number inside the range.
By their numbers in this assay, from the lowest: compounds 1, 3, 2 and 4 (each within the scatter of the next).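

In this assay, (methoxycarbonyl)methyl on the amine nitrogen gives a 1.6-fold higher number from compound 3 to compound 4 (0.21 log units; within the scatter), so replacing tert-butyl, a group made only of carbon and hydrogen, with one containing two oxygens and two hydrogen-bond acceptors produces no step beyond the scatter. Within the data shown here, the other two comparisons agree, with a 1.0-fold higher number from compound 2 to compound 4 (0.01 log units; within the scatter) and a 1.8-fold higher number from compound 1 to compound 4 (0.25 log units; within the scatter), which extends the flat picture from the carbon-only groups of the earlier compounds to an ester-bearing chain, and all four compounds now sit within the scatter of their neighbours in the ranking. No supporting measurement bears on why the number stays within the scatter after this change.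

With every step this small, the four compounds do not show whether the group on this nitrogen influences antiproliferative activity in this assay at all, or whether the flat picture merely reflects the narrow set of groups compared. As far as these compounds go, a carboxylic acid in place of the methyl ester, a longer chain between the amine nitrogen and the ester, or an aromatic ring on that nitrogen would test this more sharply, and the outcome of any of them remains open.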